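Amino in Place of Methyl on the Aryl Ring

The source may hold more compounds than are shown below. What is called first, only, known or untested is meant among the compounds shown, and "the series" means these compounds.

Measured so far:
- compound 1, `Nc1ccc(-c2cc(Cl)cc(C(=O)Nc3nn[nH]n3)n2)cc1`: 100%
- compound 2, `Cc1ccc(-c2cccc(C(=O)Nc3nn[nH]n3)n2)cc1`: 67%

Both compounds were tested in a functional assay on the whole organism with Rattus norvegicus as the target, at a dose of 1 mg/kg by the oral route; on this read-out lower numbers stand for a weaker effect and higher numbers for a stronger effect at the one dose given. Compound 1 gives 100% in this assay, and compound 2 gives 67%. Compound 2 therefore stands at the lower of the two numbers, and its distance from compound 1 lies beyond the usual scatter. Going by the values given here, compound 1 and compound 2 differ in more than one place, so no single step between them can be read off; their two values are all that is known.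

The unmeasured compound 3, `Nc1ccc(-c2cccc(C(=O)Nc3nn[nH]n3)n2)cc1`, differs from compound 2 in one place: amino in place of methyl on an aromatic carbon. The change is small in atom count, and nothing measured here isolates what an amino in place of a methyl does by itself. Among the compounds with values here, the only guide is that compound 1, which carries the amino group, shows the higher value.

On that basis compound 3 is expected to give 85% in this assay, with a plausible range of 62% to 100%. The step from compound 2 expected for it is a number 18 percentage points higher from compound 2 to compound 3 (beyond the scatter), upward and probably beyond the scatter.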

Compound 3, a percentage reported as inhibition, in the whole organism at one dose (the size of the read-out at that dose, not a potency): 62%
Estimate against measurement, compound 3: 23 percentage points above, and the stated range covers the measured number.
By their numbers in this assay, from the lowest: compounds 3 and 2 (each within the scatter of the next); then compound 1.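

In this assay, going from 4-methylphenyl to 4-aminophenyl on a core without chloro gives a number 5 percentage points lower from compound 2 to compound 3 (within the scatter) and so leaves the two groups indistinguishable at the one dose given: the amino group alone does not bring the stronger effect that compound 1 seemed to suggest. The large difference appears at a different place on the core, since hydrogen in place of chloro on an aromatic carbon, with the amino group kept, gives a number 38 percentage points lower from compound 1 to compound 3 (beyond the scatter) and ties the stronger effect of compound 1 to the presence of chloro in this amino series. Nothing shown gives a reason for either step.

The compounds shown leave open whether chloro would bring a similar gain with methyl rather than amino on the aryl ring, so it remains unclear whether its effect depends on the amino group. They also leave open what other groups would do, such as fluoro or methoxy in place of chloro, or hydroxyl or a dimethylamino group in place of the amino group.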